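The source may hold more compounds than are shown below. What is called first, only, known or untested is meant among the compounds shown, and "the series" means these compounds.

Measured compounds:

Compound 1 `COc1ccc(-n2nncc2CN2C(=O)C3(C(C#N)=C(N)Oc4c3c3nc5ccccc5nc3c3ccccc43)c3ccccc32)cc1`: in a functional assay on A549 cells (Homo sapiens) for antiproliferative activity, read by MTT assay, with a stated time of 48 h (on this read-out lower numbers stand for stronger inhibition and higher numbers for weaker inhibition), compound 1 gives > 50000 nM, a limit of the assay.
Compound 2 `Cc1ccc(-n2nncc2CN2C(=O)C3(C(C#N)=C(N)Oc4c3c3nc5ccccc5nc3c3ccccc43)c3ccccc32)cc1Cl`: in this assay compound 2 gives > 50000 nM, also a limit of the assay.
Compound 3 `N#CC1=C(N)Oc2c(N)cc3nc4ccccc4nc3c2C12C(=O)N(Cc1cnnn1-c1cccc(Br)c1)c1ccccc12`: in this assay compound 3 gives 18900 nM.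

Compound 3 is therefore the only one of the three with a number in this assay; the other two sit at the limit of > 50000 nM in this assay, at which 2 of the 3 values shown sit. For the measured compounds named here, the one change between measured compounds, a step that the two limits leave unreadable from compound 1 to compound 2, cannot be read because both of its ends are limits.

Compound 4 `N#CC1=C(N)Oc2c(N)cc3nc4ccccc4nc3c2C12C(=O)N(Cc1cnnn1-c1ccc([N+](=O)[O-])cc1)c1ccccc12` differs from compound 3 in one place: 4-nitrophenyl in place of 3-bromophenyl on an aromatic nitrogen. No measured change touches this position with a readable size, so the account has nothing to lean on beyond the value of compound 3 itself. The expectation for compound 4 is accordingly a step of a 1.0-fold higher number from compound 3 to compound 4 (0.00 log units; within the scatter) in this assay, that is, none beyond the usual scatter. Compound 4 is estimated at 19000 nM in this assay, with a range from 6000 nM to 50000 nM, and a real chance that the assay reports only a limit.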

Compound 4, half-maximal inhibitory concentration: > 50000 nM
Compound 4 ended at the assay's limit; the forecaster's own chance of this, stated with the estimate: 35%; middle value at least 2.6-fold (0.42 log units) from the limit.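

The aryl group on the aromatic nitrogen of the five-membered ring does matter in this assay: 4-nitrophenyl in place of 3-bromophenyl gives an at least 2.6-fold higher number from compound 3 to compound 4 (0.42 log units; beyond the scatter), the first readable size for any change at this position. The earlier step at this position, between compound 1 and compound 2, cannot be read, as both of its ends are limits. Compound 4 itself gives only a limit, so the new step sets a minimum and not a full size, and compound 4 joins the other compounds that end there: the limit of > 50000 nM in this assay, at which 3 of the 4 values shown sit.

With only the 3-bromophenyl and 4-nitrophenyl groups to compare on this core, the compounds shown cannot separate the effect of removing the bromine, that of adding the nitro group and that of moving the substituent around the phenyl ring. On these data alone, it remains open how a plain phenyl, 4-bromophenyl, 3-nitrophenyl or 4-aminophenyl group on the same nitrogen would stand against compound 3, and whether any group there would give a clearly lower number.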